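This account rests on a few compounds, and the source may have more. Where it says the series, first, only, none or still open, it means among the compounds named here.

Measured in an ADME assay on L1210/0 cells (Mus musculus) for cytotoxicity, with a stated time of 48 h (on this read-out higher numbers stand for weaker inhibition and lower numbers for stronger inhibition), all values being limits:
- compound 1 `OC[C@@H]1C[C@H](Cn2cnc3c(Cl)ncnc32)c2c(-c3ccccc3)nnc(-c3ccccc3)c21`: > 200000 nM
- compound 2 `CC(O)Cn1cnc2c(N)nc(I)nc21`: > 200000 nM
- compound 3 `CC(O)Cn1cnc2c(Cl)nc(I)nc21`: > 200000 nM

Compound 2 stands only at a limit, > 200000 nM, with no number behind it. Compound 4 `Nc1nc(I)nc2c1ncn2COCCO` carries 2-hydroxyethoxy in place of 1-hydroxyethyl on a saturated chain carbon bound to an aromatic nitrogen. Cut one bond further out, this reads 2-hydroxypropyl to (2-hydroxyethoxy)methyl. For the measured compounds named here, the only measured step, a step that the two limits leave unreadable from compound 2 to compound 3, is chloro in place of amino on an aromatic carbon, a different change with no readable size. Going by the values given here, the series so far shows (the limit of > 200000 nM in this assay, at which 3 of the 3 values shown sit). No step beyond the scatter can therefore be expected in this assay, in either direction. The expected step is a number no higher from compound 2 to compound 4 (the limit leaves the size open). For compound 4 the estimate is 200000 nM, with an expected range of 80000 nM to 300000 nM.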

Compound 4, half-maximal inhibitory concentration: > 200000 nM
Compound 4 gave a limit, no number; the forecaster's own chance of this, stated with the estimate: 75%; the middle value lies on the limit itself.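

No step can be read from compound 2 to compound 4, as both values are limits and not numbers: the limit of > 200000 nM in this assay, at which 4 of the 4 values shown sit. The compounds shown leave open whether any change to this series gives a number rather than a limit.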